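This account rests on a few compounds, and the source may have more. Where it says the series, first, only, none or still open, it means among the compounds named here.

Compound 1 `C[C@](N)(COP(=O)(O)O)C(=O)Nc1ccc(Oc2ccc(-c3ccccc3)cc2)cc1` is measured in an assay on isolated protein for displacement of a labelled ligand from sphingosine 1-phosphate receptor 5 (Homo sapiens) (a higher number here means a weaker inhibitor, a lower number a stronger inhibitor), where compound 1 gives 455 nM. Compound 2 `C[C@](N)(COP(=O)(O)O)C(=O)Nc1ccc(OCCc2cccc3ccccc23)cc1` shares the same core, but in this assay compound 2 stands at "not determined" (no result reported), so no number anchors it. Compound 3 `C[C@](N)(COP(=O)(O)O)C(=O)Nc1ccc(OCCCCC2CCCCC2)cc1` differs from compound 2 by 2-cyclohexylethyl in place of naphthalen-1-yl on a saturated chain carbon, two bonds along the chain from an oxygen on an aromatic ring. For the measured compounds named here, with no measured step to lean on, the size and direction of the change cannot be foreseen from these data. Compound 3 is expected to reach about 300 nM, estimated between 60 nM and 1500 nM.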

Compound 3, half-maximal inhibitory concentration: 26.2 nM
Beside the measured number, compound 3's estimate is 11-fold (1.06 log units) above it; measured number below the stated range.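

In this assay no step can be read between compound 2 and compound 3. On these data alone, whether naphthalen-1-yl or 2-cyclohexylethyl gives the stronger inhibitor stays open, and no evidence at hand bears on the result.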